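Compound 2 to compound 3: a (trifluoromethyl)sulfanyl change

The source may hold more compounds than are shown below. What is called first, only, known or untested is meant among the compounds shown, and "the series" means these compounds.

Within the data shown here, in a physicochemical assay for solubility, at pH 7.4 (on this read-out lower numbers stand for lower solubility and higher numbers for higher solubility), compound 1 (`CCc1ccc(NC(=O)Nc2cc(C)nc3ccccc23)cc1`) gives 3300 nM and compound 2 (`Cc1cc(NC(=O)Nc2ccc(C(F)(F)F)cc2)c2ccccc2n1`) gives 100 nM, the lower of the two numbers so far. Compound 3 (`Cc1cc(NC(=O)Nc2ccc(SC(F)(F)F)cc2)c2ccccc2n1`) is not yet measured. It carries (trifluoromethyl)sulfanyl in place of trifluoromethyl on an aromatic carbon, para to a large group: (trifluoromethyl)sulfanyl in place of trifluoromethyl on an aromatic carbon. Among the measured compounds shown here, only one measured step bears on this, at the same place: a 33-fold lower number from compound 1 to compound 2 (1.52 log units; beyond the scatter), a large step beyond the scatter, with trifluoromethyl in place of ethyl. That step involves a different exchange, so it guides direction only loosely. A smaller further fall in this assay is expected, close to the edge of the scatter. The expected change is a 2.0-fold lower number from compound 2 to compound 3 (0.30 log units; within the scatter). The estimated value for compound 3 is 50 nM, with an expected range of 15 nM to 170 nM.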

Compound 3, solubility: 200 nM
Estimate against measurement, compound 3: 4.0-fold (0.60 log units) below; measured number outside the range, above it.
By their numbers in this assay, from the lowest: compounds 2 and 3 (each within the scatter of the next); then compound 1.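

At this aromatic carbon, para to a large group, this assay does not separate (trifluoromethyl)sulfanyl from trifluoromethyl: a 2.0-fold higher number from compound 2 to compound 3 (0.30 log units; within the scatter) stays within the scatter. Against ethyl, the picture is different, with a 17-fold lower number from compound 1 to compound 3 (1.22 log units; beyond the scatter) showing that the large gap first seen with trifluoromethyl also appears with a second group carrying three fluorines, and compound 1 stands apart from both compound 2 and compound 3 in this series. No measurement at hand gives a reason for either step.

Open, as far as these compounds go, is how an amine or a carboxylic acid at this carbon would read in this assay beside these three compounds. Also open, from the compounds shown here alone, is whether methoxy or a longer chain than ethyl would sit near compound 1 or near compound 2 and compound 3.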